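The compounds below may be only part of what the source reports. "The series", "measured", "known", "first", "only" and "open" are said of these compounds alone.

Measured so far in an in vitro ADME assay on microsomes from liver (Homo sapiens) for metabolic stability; a higher number here means faster removal of the compound, a lower number slower removal:

compound 1 `O=C(Nc1cccnc1-c1ccccc1)N1CCN2C(=O)N([C@H]3C[C@@H]3c3ccccc3)C(=O)[C@@H]2C1` — 45000 mL.min-1.g-1
compound 2 `O=C(Nc1cccnc1-c1cccc(Cl)c1)N1CCN2C(=O)N([C@H]3C[C@@H]3c3ccccc3)C(=O)[C@@H]2C1` — 90000 mL.min-1.g-1
compound 3 `O=C(Nc1c(Cl)cc(F)cc1Cl)N1CCN2C(=O)N([C@H]3C[C@@H]3c3ccccc3)C(=O)[C@@H]2C1` — 64000 mL.min-1.g-1

Compound 3 sits between compound 1 and compound 2, and its gap to either lies within the scatter of repeated measurements, so the three numbers cannot be told apart with confidence. Compound 4 `N#Cc1cc(Cl)c(NC(=O)N2CCN3C(=O)N([C@H]4C[C@@H]4c4ccccc4)C(=O)[C@@H]3C2)c(Cl)c1` differs from compound 3 in one place: cyano in place of fluoro on an aromatic carbon. Within the data shown here, the only measured step, a 2.0-fold higher number from compound 1 to compound 2 (0.30 log units; within the scatter), swaps chloro for hydrogen on a different ring and says nothing about cyano replacing fluoro; no measured pair bears directly on this change. With no evidence for movement, the step of no change at the digits printed from compound 3 to compound 4 (within the scatter) is expected to stay within the scatter. Compound 4 is therefore estimated at 64000 mL.min-1.g-1, with a range from 32000 mL.min-1.g-1 to 128000 mL.min-1.g-1.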

Compound 4, intrinsic clearance in microsomes: 66000 mL.min-1.g-1
Estimate against measurement, compound 4: 1.0-fold (0.01 log units) below; measured number inside the range.
By their numbers in this assay, from the lowest: compounds 1, 3, 4 and 2 (each within the scatter of the next).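

In this assay, among these compounds, replacing 2,6-dichloro-4-fluorophenyl with 2,6-dichloro-4-cyanophenyl gives a 1.0-fold higher number from compound 3 to compound 4 (0.01 log units; within the scatter), the first reading of a swap at this position. Compound 3 and compound 4 therefore cannot be told apart here, although cyano brings one more heavy atom than fluoro and a hydrogen-bond acceptor. No supporting measurement offers an explanation for this result. Still open, on these data alone, is whether an amine or a carboxylic acid at this position would separate from compound 3. Also open, as far as these compounds go, is whether cyano in place of fluoro would read the same on another ring.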